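The source may hold more compounds than are shown below. What is called first, only, known or untested is meant among the compounds shown, and "the series" means these compounds.

Compound 3 `Cn1c(-c2ccc(NC(=O)CSC3=NCCS3)cc2)nc(-c2ccccc2)c1-c1ccccc1` gives the lowest of the three numbers measured in a functional assay on HT-29 cells (Homo sapiens) for cytotoxicity, read by MTT assay, with a stated time of 24 h, tested at 80 ug/mL; on this read-out lower numbers stand for a weaker effect and higher numbers for a stronger effect at the one concentration tested: compound 3 gives 75.2%. Compound 1 `Cn1c(-c2ccc(NC(=O)CSc3nc4ccccc4o3)cc2)nc(-c2ccccc2)c1-c1ccccc1` gives 81.5% in this assay, and compound 2 `Cn1nnnc1SCC(=O)Nc1ccc(-c2nc(-c3ccccc3)c(-c3ccccc3)n2C)cc1` gives 89% in this assay. Of the two steps that end at compound 3, one is a number 13.8 percentage points lower from compound 2 to compound 3 (beyond the scatter) and the other is a number 6.3 percentage points lower from compound 1 to compound 3 (within the scatter).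

Compound 4 `Cn1ccnc1SCC(=O)Nc1ccc(-c2nc(-c3ccccc3)c(-c3ccccc3)n2C)cc1` is not yet measured. It differs from compound 3 in one place: a group of 6 heavy atoms (4 carbon, 2 nitrogen; one five-membered aromatic ring with 2 hetero atoms) in place of a group of 5 heavy atoms (3 carbon, 1 nitrogen, 1 sulfur; one five-membered non-aromatic ring with 2 hetero atoms), on a sulfur. Both steps that lead into compound 3 replace an aromatic five-membered ring on that sulfur with the non-aromatic ring of compound 3, and both go downward, one beyond the scatter and one within it. Compound 4 reverses this kind of change by putting an aromatic five-membered ring back on the sulfur, so a modest upward step is expected, of the size of a number 7.8 percentage points higher from compound 3 to compound 4 (within the scatter). For compound 4 the expected value in this assay is 83%, estimated to fall between 72% and 92%.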

Compound 4, a percentage reported as activity, at one concentration (the size of the read-out at that concentration, not a potency): 69.4%
For compound 4 the middle estimate is 13.6 percentage points above the measured one; measured number below the stated range.
By their numbers in this assay, from the lowest: compounds 4, 3, 1 and 2 (each within the scatter of the next, the first and the last beyond it).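

In this assay, putting an aromatic five-membered ring back on this sulfur does not by itself bring back the higher numbers: the 1-methyl-1H-imidazol-2-yl group gives a number 5.8 percentage points lower from compound 3 to compound 4 (within the scatter) and so is not told apart from the non-aromatic ring of compound 3. The identity of the aromatic group does count at this position, as a number 19.6 percentage points lower from compound 2 to compound 4 (beyond the scatter) and a number 12.1 percentage points lower from compound 1 to compound 4 (beyond the scatter) both separate 1-methyl-1H-imidazol-2-yl from the groups it replaces, while 1-methyl-1H-tetrazol-5-yl and 1,3-benzoxazol-2-yl remain within the scatter of each other. Nothing available here gives a measured reason for these differences.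

Open, as far as these compounds go, is how this sulfur position responds to a group without a ring, such as an amine or a carboxylic acid on a short chain. Also open, from the compounds shown here alone, is whether the order seen at this one concentration would hold at other concentrations.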